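Two Chlorines on the Pendant Phenyl: What to Expect

A few compounds are considered here, and "the series" means these few. Any claim that something is new, unique, unknown or untested is made for them only; others in the source may bear on it.

For the measured compounds named here, compound 2 `COc1cccc(COc2ccc3cc(C(=O)/C=C/c4ccccc4)c(=O)oc3c2)c1` is the only compound with a numerical reading in a functional assay on MCF7 cells (Homo sapiens) for cytotoxicity, read by MTT assay, with a stated time of 72 h (a lower number here means a stronger inhibitor, a higher number a weaker inhibitor), where compound 2 gives 33700 nM. Its relative compound 1 `COc1cccc(COc2ccc3cc(C(=O)/C=C/c4ccc(C)cc4)c(=O)oc3c2)c1` carries a methyl on an aromatic carbon. In this assay compound 1 reaches only a limit of the assay, > 50000 nM, the limit described in the limit of > 50000 nM in this assay, at which 1 of the 2 values shown sits. Going by the values given here, the one measured step reads an at least 1.4-fold lower number from compound 1 to compound 2 (0.17 log units; that floor lies within the scatter). Compound 3 `COc1cccc(COc2ccc3cc(C(=O)/C=C/c4c(Cl)cccc4Cl)c(=O)oc3c2)c1` differs from compound 2 by 2,6-dichlorophenyl in place of phenyl on a double-bonded chain carbon bound to a double-bonded chain carbon. Among the compounds with values here, only the step from compound 1 to compound 2 concerns a change on an aromatic carbon of that phenyl, and it was small; no measured step involves chlorine. Compound 3 is therefore expected to sit near compound 2. The step of a 1.1-fold lower number from compound 2 to compound 3 (0.05 log units; within the scatter) is expected to stay within the scatter. The estimate for compound 3 in this assay is 30000 nM, with a range from 10000 nM to 90000 nM.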

Compound 3, half-maximal inhibitory concentration: 10100 nM
The estimate for compound 3 lay 3.0-fold (0.47 log units) above the measured number; the measured number falls inside the stated range.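

For the compounds shown here, replacing phenyl with 2,6-dichlorophenyl gives a 3.3-fold lower number from compound 2 to compound 3 (0.52 log units; beyond the scatter) in this assay and is the first step here to lie beyond the scatter. This shows that the number can respond to a change in the ring held on this double-bonded chain carbon, which the small step from methyl to hydrogen could not show. Set against 4-methylphenyl, the same group gives an at least 4.9-fold lower number from compound 1 to compound 3 (0.69 log units; beyond the scatter) as a floor only, and the end of that step at compound 1 is a limit of the assay: the limit of > 50000 nM in this assay, at which 1 of the 3 values shown sits.

From the compounds shown here alone, whether a single chlorine would do as much as two remains open, as does whether the chlorines must sit where they do in 2,6-dichlorophenyl. Going by these compounds, how a ring carrying an amine or a carboxylic acid would read also stays unknown.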